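The compounds below may be only part of what the source reports. "The series", "measured", "known", "first", "only" and "open" are said of these compounds alone.

Working notes on the series. Of the compounds shown here, three have been measured in an assay on isolated protein for binding affinity to L-selectin (Homo sapiens), read by ELISA, tested at 500 uM; a lower number here means less inhibition, a higher number more inhibition at the concentration tested (going by the name of the read-out). Compound 1 `CCCCCCCCCCOc1cccc(OCCCCCC(=O)N(Cc2ccc(C(=O)OC)cc2)c2ccc(C(=O)OC)cc2)c1` gives 75%. Compound 2 `CCCCCCCCCCOc1cc(OCCCCCCCCCC)cc(OCCCCCC(=O)N(c2ccc(C(=O)OC)cc2)c2ccc(C(=O)OC)c(C(=O)OC)c2)c1` gives 95%. Compound 3 `O=C(O)c1ccc(N(C(=O)CCCCCBr)c2ccc(C(=O)O)cc2)cc1` gives 6%, the lowest of the three numbers: the nearest is compound 1, whose number is higher by a gap beyond the usual scatter, and compound 2 stands further above it again, also beyond the scatter.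

Compound 4 `O=C(O)c1ccc(N(C(=O)CCCCCBr)c2cccc(C(=O)O)c2)cc1` has not yet been measured in this assay. It differs from compound 3 in one place: 3-carboxyphenyl in place of 4-carboxyphenyl on an amide-type nitrogen. The two have the same atoms, joined differently. For the measured compounds named here, no pair of measured compounds that differ in a single place exists, so the weight of such a change cannot be read from the data at hand. Going by the values given here, the only anchor is compound 3 itself, whose reading in this assay sits close to the floor of the read-out, leaving little room for a fall. The step of a number 2 percentage points higher from compound 3 to compound 4 (within the scatter) is therefore expected to stay within the scatter, with no direction claimed. For compound 4 the estimate is 8%, expected to lie between 0% and 25%.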

Compound 4, a percentage reported as inhibition, at one concentration (the size of the read-out at that concentration, not a potency): 5%
Beside the measured number, compound 4's estimate is 3 percentage points above it; low and high end bracket the measured number.
By their numbers in this assay, from the lowest: compounds 4 and 3 (each within the scatter of the next); then compound 1; then compound 2.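

In this assay, for the compounds shown here, 3-carboxyphenyl in place of 4-carboxyphenyl on an amide-type nitrogen gives the first single-place step, a number 1 percentage points lower from compound 3 to compound 4 (within the scatter), so this change leaves no readable mark at this position. The reading holds only for this bromo-ended scaffold: compound 3 gives 6% and compound 4 gives 5%, both numbers so small that a loss could hardly show. No measurement bearing on the reason for this result is at hand.

Going by these compounds, whether a sulfonic acid or an amine in place of the carboxylic acid of compound 4 would lift the reading stays open. Also open, on these data alone, is whether the same exchange would read alike on a compound with a much larger number, such as compound 1 at 75%.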